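Fluoro in place of methoxy on an inactive dithiocarbamate series

The compounds below may be only part of what the source reports. "The series", "measured", "known", "first", "only" and "open" are said of these compounds alone.

Compound 1, `COc1ccc(-n2cc(CSC(=S)N3CCN(C(=O)OC(C)(C)C)CC3)nn2)cc1`, gives in a functional assay on PC-3 cells (Homo sapiens) for inhibition, read by MTT assay, with a stated time of 72 h (on this read-out lower numbers stand for stronger inhibition and higher numbers for weaker inhibition), only a limit of the assay, > 128000 nM.
Compound 2, `O=C(OCc1ccccc1)N1CCN(C(=S)SCc2cn(Cc3ccc(Cl)cc3)nn2)CC1`, gives in this assay only a limit, > 128000 nM.
Compound 3, `COc1ccc(Cn2cc(CSC(=S)N3CCN(C(=O)OCc4ccccc4)CC3)nn2)cc1`, gives in this assay only a limit, > 128000 nM.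

All three measured compounds therefore stand at the same place: none reaches a readable half-maximal inhibitory concentration in this assay, as the limit of > 128000 nM in this assay, at which 3 of the 3 values shown sit, shows. Compound 3 is among them, and its value is a limit rather than a number. For the measured compounds named here, the one structural step between measured compounds, a step that the two limits leave unreadable from compound 2 to compound 3, cannot be read, since both ends of it are limits.

Compound 4, `O=C(OCc1ccccc1)N1CCN(C(=S)SCc2cn(Cc3ccc(F)cc3)nn2)CC1`, differs from compound 3 by fluoro in place of methoxy on an aromatic carbon. Going by the values given here, no measured step bears on this change in a readable way; the only comparable step, from compound 2 to compound 3, is itself unreadable. Given that every measured compound sits at the limit, compound 3 included with > 128000 nM, the step that the limit leaves unreadable from compound 3 to compound 4 is expected to change nothing beyond the scatter, and most likely compound 4 will again return a limit. Compound 4 is expected to give about 200000 nM in this assay, within a range from 100000 nM to 600000 nM.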

Compound 4, half-maximal inhibitory concentration: > 128000 nM
Compound 4 was reported as a limit; the forecaster's own chance of this, stated with the estimate: 90%; the middle value does not contradict the limit.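

In this assay compound 4 gives only a limit, > 128000 nM. No step can be read between compound 4 and either compound 2 or compound 3, with limits at both ends of each pair. The compounds shown leave open whether any change to this series gives a readable half-maximal inhibitory concentration, and how fluoro, chloro and methoxy rank against one another.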